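Cytotoxicity Outlook for a Benzyl(methyl)amino Analogue

This account rests on a few compounds, and the source may have more. Where it says the series, first, only, none or still open, it means among the compounds named here.

The three measured compounds share one core, varied only at the amine. In an ADME assay on Vero cells (Chlorocebus sabaeus) for cytotoxicity, read by MTT assay, with a stated time of 48 h (a higher number here means a weaker inhibitor, a lower number a stronger inhibitor), compound 1 `CN(Cc1ccc2c(c1)OCCO2)c1cc(=O)c2cc(C(F)(F)F)cc([N+](=O)[O-])c2s1` gives > 64 ug/mL, which is a limit of the assay rather than a number. Compound 2 `O=c1cc(NCc2cccc(F)c2)sc2c([N+](=O)[O-])cc(C(F)(F)F)cc12` gives > 64 ug/mL in this assay, again a limit. Compound 3 `O=c1cc(NCC2CCCCC2)sc2c([N+](=O)[O-])cc(C(F)(F)F)cc12` gives > 64 ug/mL in this assay, likewise a limit. Among the measured compounds shown here, the only step between measured neighbours, a step that the two limits leave unreadable from compound 2 to compound 3, is therefore unreadable. Compound 3 thus stands where every value of the set stands, at the limit of > 64 ug/mL in this assay, at which 3 of the 3 values shown sit, with no number to rank it against the others.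

Compound 4 `CN(Cc1ccccc1)c1cc(=O)c2cc(C(F)(F)F)cc([N+](=O)[O-])c2s1` differs from compound 3 by benzyl(methyl)amino in place of (cyclohexylmethyl)amino on an aromatic carbon. For the measured compounds named here, no measured step with a readable size bears on this change; the one step available is a comparison of two limits. Nothing in the data points to a step beyond the usual scatter, and compound 4 is expected to remain at the limit of this assay. Compound 4 is accordingly estimated at 100 ug/mL, in the range 48 ug/mL to 250 ug/mL. The estimated step that the limit leaves unreadable from compound 3 to compound 4 is expected to lie within the scatter.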

Compound 4, half-maximal inhibitory concentration: > 64 ug/mL
Compound 4 was reported as a limit; the forecaster's own chance of this, stated with the estimate: 80%; the middle value does not contradict the limit.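

In this assay compound 4 gives > 64 ug/mL, which is a limit. Its steps from compound 1, compound 2 and compound 3 each join two limits, so none can be read. The compounds shown leave open whether any of these changes at the amine shifts the read-out at all: the limit of > 64 ug/mL in this assay, at which 4 of the 4 values shown sit.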